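Working notes: tert-butyl variant of compound 3

The compounds below may be only part of what the source reports. "The series", "measured", "known", "first", "only" and "open" are said of these compounds alone.

compound 1 `CCCCc1cnc(C(CCC)Cc2ccc(-c3ccccc3C(=O)O)cc2)[nH]1` — 165 nM
compound 2 `CCCCc1cnc(CCCc2ccc(-c3ccccc3C(=O)O)cc2)[nH]1` — 382 nM
compound 3 `COc1ccc(Cc2cnc(CCc3ccc(-c4ccccc4C(=O)O)cc3)[nH]2)cc1` — 513 nM

All three were run in an in vitro functional assay on cells for agonist activity at Bombesin receptor subtype-3 (Mus musculus), read by luminescence and calcium flux; on this read-out higher numbers stand for an effect only at larger amounts of compound and lower numbers for an effect already at smaller amounts. Compound 3 carries the highest number of the three; its gap to compound 2 lies within the scatter, whereas compound 1 stands beyond it with a clearly lower number. Within the data shown here, no single-point step between measured compounds is defined, so the values can only be set side by side. Compound 4 `CC(C)(C)Cc1cnc(CCc2ccc(-c3ccccc3C(=O)O)cc2)[nH]1` is not yet measured; it differs from compound 3 by tert-butyl in place of 4-methoxyphenyl on a saturated chain carbon bound to an aromatic carbon. Given compound 1 at 165 nM and compound 2 at 382 nM, both carrying a butyl chain on the core, a saturated group in this position is expected to give a number close to that of compound 3. The step of a 1.3-fold lower number from compound 3 to compound 4 (0.11 log units; within the scatter) is expected to stay within the scatter. For compound 4 the expected value in this assay is 400 nM, with a range from 130 nM to 1200 nM.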

Compound 4, half-maximal effective concentration: 6.3 nM
Estimate against measurement, compound 4: 63-fold (1.80 log units) above; measured number below the stated range.
By their numbers in this assay, from the lowest: compound 4; then compound 1; then compounds 2 and 3 (each within the scatter of the next).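

In this assay, tert-butyl in place of 4-methoxyphenyl on a saturated chain carbon bound to an aromatic carbon gives an 81-fold lower number from compound 3 to compound 4 (1.91 log units; beyond the scatter) and so shows that the number is highly sensitive to the group at this position. The earlier compounds shown here offered no single-place step and could not show this. Nothing at hand explains the size of this step.

Still open, from the compounds shown here alone, is whether a cyclohexyl or an unsubstituted phenyl in the same place would give a number nearer that of compound 3 or compound 4.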